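Swapping 4-chlorophenyl for cyclopropyl on the ring nitrogen

The source may report more compounds than this note shows. Statements on the series, on what has been measured and on what is new or still open speak of the compounds shown alone.

compound 1 `CC(C)N1C(=O)COc2ccc(-c3cnc(Cl)c(NS(=O)(=O)c4ccc(F)cc4)c3)cc21` gives 5100 nM
compound 2 `O=C1COc2ccc(-c3cnc(Cl)c(NS(=O)(=O)c4ccc(F)cc4)c3)cc2N1c1ccc(Cl)cc1` gives 21600 nM

Among the measured compounds shown here, of the two compounds measured so far in a functional assay on A549 cells (Homo sapiens) for antiproliferative activity, read by MTT assay, with a stated time of 72 h (on this read-out higher numbers stand for weaker inhibition and lower numbers for stronger inhibition), compound 2 has the higher number, which makes it the weaker inhibitor of the pair. The next change leads to compound 3 `O=C1COc2ccc(-c3cnc(Cl)c(NS(=O)(=O)c4ccc(F)cc4)c3)cc2N1C1CC1` with cyclopropyl in place of 4-chlorophenyl on an amide-type nitrogen in a ring and the rest of the structure unchanged.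

For the measured compounds named here, one measured step bears on this change. With 4-chlorophenyl in place of isopropyl at that same nitrogen, the data show a 4.2-fold higher number from compound 1 to compound 2 (0.63 log units; beyond the scatter) as a modest step beyond the scatter. Going by the values given here, no cyclopropyl compound has been measured yet, so the reading rests on compound 1 alone, whose isopropyl is the nearest measured group to cyclopropyl. Removing the 4-chlorophenyl is therefore expected to give a step of similar size in the opposite direction, towards a lower number in this assay on this basis.

Compound 3 is estimated at 6500 nM with an expected range of 2500 nM to 16000 nM in this read-out. The estimate means a 3.3-fold lower number from compound 2 to compound 3 (0.52 log units; beyond the scatter) as the expected step.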

Compound 3, half-maximal inhibitory concentration: 4330 nM
For compound 3 the middle estimate is 1.5-fold (0.18 log units) above the measured one; the range from low to high includes it.
By their numbers in this assay, from the lowest: compounds 3 and 1 (each within the scatter of the next); then compound 2.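

In this assay, the step back from the aromatic group gives a 5.0-fold lower number from compound 2 to compound 3 (0.70 log units; beyond the scatter), opposite in direction to a 4.2-fold higher number from compound 1 to compound 2 (0.63 log units; beyond the scatter), so among these three compounds the 4-chlorophenyl compound stands alone at the higher number and neither small carbon group on the amide-type nitrogen goes against this. The change from the open isopropyl to the closed cyclopropyl gives a 1.2-fold lower number from compound 1 to compound 3 (0.07 log units; within the scatter), so these two groups cannot be told apart at this position in this read-out, and the ring in the cyclopropyl group brings no measurable gain or loss here. Nothing in the available data accounts for the difference between the 4-chlorophenyl compound and the two small-group compounds.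

Among the compounds shown here, with only one aromatic group in the set, it stays open whether the higher number goes with the benzene ring itself or with its chlorine, which a plain phenyl on the same nitrogen would separate. Also open is how this nitrogen responds to a group of a different kind, such as a dimethylaminoethyl chain or a chain ending in a carboxylic acid, since all three groups shown are hydrocarbon-based and carry no donors or acceptors.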